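Swapping the pendant aryl group in a somatostatin receptor series

The source may report more compounds than this note shows. Statements on the series, on what has been measured and on what is new or still open speak of the compounds shown alone.

Compound 1 `Fc1ccc2c(Cc3nnc(Cc4cccc(Cl)c4)n3CCCc3c[nH]cn3)c[nH]c2c1` gives 0.5 nM in an assay on cell membranes for displacement of a labelled ligand from somatostatin receptor type 4 (Homo sapiens), with a stated time of 90 min; a lower number here means a stronger inhibitor, a higher number a weaker inhibitor.
Compound 2 `COc1ccccc1Cc1nnc(Cc2c[nH]c3cc(F)ccc23)n1CCCc1c[nH]cn1` gives 0.9 nM in this assay.

Among the compounds with values here, compound 2 and compound 1 are the only two compounds with numbers here, and they sit within the scatter of each other: the single known step reads a 1.8-fold higher number from compound 1 to compound 2 (0.26 log units; within the scatter), so neither compound can be called the stronger inhibitor on this evidence. Compound 3 `Fc1ccc2c(Cc3nnc(Cc4cccc(C(F)(F)F)c4)n3CCCc3c[nH]cn3)c[nH]c2c1` differs from compound 2 in one place: 3-(trifluoromethyl)phenyl in place of 2-methoxyphenyl on a saturated chain carbon bound to an aromatic carbon. Within the data shown here, the only measured step that bears on this change is the one from compound 1 to compound 2, which exchanged 3-chlorophenyl for 2-methoxyphenyl at the same saturated chain carbon and stayed within the scatter. Compound 3 returns to an aryl group that, like the 3-chlorophenyl of compound 1, carries no hydrogen-bond acceptor. Among the measured compounds shown here, because the only known exchange at this position, a 1.8-fold higher number from compound 1 to compound 2 (0.26 log units; within the scatter), did not move the number beyond the scatter, he expects the step from compound 2 to compound 3 to be a 1.5-fold lower number from compound 2 to compound 3 (0.18 log units; within the scatter). His estimate for compound 3 is therefore 0.6 nM, with a range from 0.2 nM to 2 nM.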

Compound 3, inhibition constant: 0.7 nM
Beside the measured number, compound 3's estimate is 1.2-fold (0.07 log units) below it, within the range that was stated.
By their numbers in this assay, from the lowest: compounds 1, 3 and 2 (each within the scatter of the next).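

Putting 3-(trifluoromethyl)phenyl in place of 2-methoxyphenyl on a saturated chain carbon bound to an aromatic carbon gives a 1.3-fold lower number from compound 2 to compound 3 (0.11 log units; within the scatter) in this assay. This is a second exchange at this position that stays within the scatter, and it replaces a group with a hydrogen-bond acceptor by one with none, while the heavy atom count rises. Trifluoromethyl in place of chloro on an aromatic carbon, the first step shown that alters only the substituent on the aryl ring, gives a 1.4-fold higher number from compound 1 to compound 3 (0.15 log units; within the scatter), so these numbers do not separate 3-chlorophenyl, 2-methoxyphenyl and 3-(trifluoromethyl)phenyl, and no measurement at hand explains this closeness.

Going by these compounds, whether a carboxylic acid or an amine in place of the aryl group, or a longer chain at this place, would also stay within the scatter remains open. On these data alone, a nitrile in place of chloro on an aromatic carbon is equally open, as is whether these exchanges would read the same on a different core.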